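The compounds below may be only part of what the source reports. "The series", "measured", "known", "first", "only" and "open" are said of these compounds alone.

Compound 1 `O=C1O/C(=C\Cn2cc(Cc3ccccc3)nn2)C(OCc2ccccc2)=C1OCc1ccccc1`: 83100 nM
Compound 2 `O=C1O/C(=C\Cn2cc(C3=CCCCC3)nn2)C(OCc2ccccc2)=C1OCc1ccccc1`: > 100000 nM

Both values come from a functional assay on HCT-116 cells (Homo sapiens) for antiproliferative activity, read by MTT assay, with a stated time of 24 h; a higher number here means a weaker inhibitor, a lower number a stronger inhibitor. For compound 2 the figure > 100000 nM is a limit of the assay, not a number. Among the measured compounds shown here, the single measured step, an at least 1.2-fold higher number from compound 1 to compound 2 (0.08 log units; that floor lies within the scatter), is bounded by the limit of > 100000 nM in this assay, at which 1 of the 2 values shown sits. Compound 3 `O=C1O/C(=C\Cn2cc(-c3ccccn3)nn2)C(OCc2ccccc2)=C1OCc1ccccc1` differs from compound 2 by pyridin-2-yl in place of cyclohex-1-en-1-yl on an aromatic carbon. For the measured compounds named here, no measured step covers this particular change, and both measured compounds sit at the weak end of this assay. The step of a number no higher from compound 2 to compound 3 (the limit leaves the size open) is therefore expected to remain within the scatter. Compound 3 is expected to give 100000 nM, in the range 30000 nM to 300000 nM.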

Compound 3, half-maximal inhibitory concentration: > 100000 nM
Compound 3 ended at the assay's limit; the forecaster's own chance of this, stated with the estimate: 55%; the middle value lies on the limit itself.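

Pyridin-2-yl, an aromatic ring with a hydrogen-bond acceptor, shows a second kind of ring on this aromatic carbon, and it gives an at least 1.2-fold higher number from compound 1 to compound 3 (0.08 log units; that floor lies within the scatter). The step between compound 2 and compound 3 cannot be read, since both values are limits. Neither ring brings a readable gain in this assay, and the comparison stays coarse: the limit of > 100000 nM in this assay, at which 2 of the 3 values shown sit.

As far as these compounds go, how far compound 2 and compound 3 lie past that limit stays open. So does whether an aminomethyl group or a carboxylic acid on this aromatic carbon would give a readable value.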